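A few compounds are considered here, and "the series" means these few. Any claim that something is new, unique, unknown or untested is made for them only; others in the source may bear on it.

In a functional assay (strain AB) with Danio rerio as the target, read by microscopy, with a stated time of 1 h (on this read-out higher numbers stand for an effect only at larger amounts of compound and lower numbers for an effect already at smaller amounts), compound 2 `C[N+]1(CC2CCC2)CCc2c(sc(NC(=O)Nc3ccc(Cl)cc3)c2C(N)=O)C1` gives 210 nM, the lowest of the three numbers in hand. Compound 1 `CC[N+]1(C)CCc2c(sc(NC(=O)Nc3ccc(Cl)cc3)c2C(N)=O)C1` gives 1960 nM and compound 3 `CCN1CCc2c(sc(NC(=O)Nc3cccc(C#N)c3)c2C(N)=O)C1` gives 10300 nM. Within the data shown here, the only measured single-point step, a 9.3-fold lower number from compound 1 to compound 2 (0.97 log units; beyond the scatter), concerns the same saturated chain carbon bound to an amine nitrogen in a ring. Compound 4 `CC(C)C[N+]1(C)CCc2c(sc(NC(=O)Nc3ccc(Cl)cc3)c2C(N)=O)C1` carries isopropyl in place of cyclobutyl on a saturated chain carbon bound to an amine nitrogen in a ring. Among the measured compounds shown here, the change moves back toward compound 1, toward a smaller group, though not all the way, so a step in this assay partly reversing a 9.3-fold lower number from compound 1 to compound 2 (0.97 log units; beyond the scatter) is the expectation; no measured step separates a chain from a ring at this place. Compound 4 is therefore estimated at 420 nM, range 150 nM to 1200 nM, the expected step being a 2.0-fold higher number from compound 2 to compound 4 (0.30 log units; within the scatter).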

Compound 4, half-maximal effective concentration: 380 nM
Compound 4: the middle estimate sits 1.1-fold (0.04 log units) above what was measured, and the stated range covers the measured number.
By their numbers in this assay, from the lowest: compounds 2 and 4 (each within the scatter of the next); then compound 1; then compound 3.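

In this assay, a chain in place of a ring at this carbon gives a 1.8-fold higher number from compound 2 to compound 4 (0.26 log units; within the scatter), so isopropyl and cyclobutyl on a saturated chain carbon bound to an amine nitrogen in a ring are not told apart here. Isopropyl in place of methyl gives a 5.2-fold lower number from compound 1 to compound 4 (0.71 log units; beyond the scatter), so a lower number at this place does not depend on a ring. No evidence on the cause accompanies these results.

Open, going by these compounds, is whether a longer chain, a cyclohexyl ring or a hydroxyl group at this carbon would hold such numbers.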